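From benzothiazole to nitrothiazole on the shared amide

The source may hold more compounds than are shown below. What is called first, only, known or untested is meant among the compounds shown, and "the series" means these compounds.

Of the compounds shown here, three built on one shared core have been tested in a functional assay on MCF7 cells (Homo sapiens) for cytotoxicity, read by sulforhodamine B assay, with a stated time of 48 h; a lower number here means a stronger inhibitor of growth, a higher number a weaker inhibitor of growth. Compound 1 `Cc1c(NC(=O)COc2ccc(/C=C3\SC(=O)NC3=O)cc2)c(=O)n(-c2ccccc2)n1C` gives only a limit, < 100000 nM. Compound 2 `Cc1cnc(NC(=O)COc2ccc(/C=C3\SC(=O)NC3=O)cc2)s1` also gives only a limit, < 100000 nM. Within the data shown here, compound 3 `O=C(COc1ccc(/C=C2\SC(=O)NC2=O)cc1)Nc1nc2ccccc2s1` is the single compound with a readable number, 25100 nM, so it is the only fixed point among the three. The step that the limit leaves unreadable from compound 2 to compound 3 cannot be sized because of the limit of < 100000 nM in this assay, at which 2 of the 3 values shown sit. Compound 4 `O=C(COc1ccc(/C=C2\SC(=O)NC2=O)cc1)Nc1ncc([N+](=O)[O-])s1` has not yet been tested; it differs from compound 3 by 5-nitro-1,3-thiazol-2-yl in place of 1,3-benzothiazol-2-yl on an amide-type nitrogen. Among the measured compounds shown here, no measured step bears on this change, since the one step that swaps this ring is unreadable, so no direction can be drawn from the data. The expected step is therefore a 1.2-fold higher number from compound 3 to compound 4 (0.08 log units; within the scatter), within the scatter. Compound 4 is estimated at 30000 nM, with a range from 8000 nM to 100000 nM.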

Compound 4, concentration for 50% growth inhibition: < 100000 nM
Compound 4 was reported as a limit (the forecaster's own chance of this, stated with the estimate: 35%); the middle value lies beyond the limit too.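

Compound 4 gives only a limit, so no step from compound 2 or compound 3 to compound 4 can be read: the limit of < 100000 nM in this assay, at which 3 of the 4 values shown sit.

On these data alone, how compound 1, compound 2 and compound 4 rank against compound 3 in this assay stays open.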